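The source may hold more compounds than are shown below. What is called first, only, known or untested is meant among the compounds shown, and "the series" means these compounds.

In an ADME assay on HepG2 cells (Homo sapiens) for cytotoxicity, read by MTT assay, with a stated time of 72 h (a higher number here means that more compound is tolerated, a lower number that less compound is tolerated), the measured compounds stand as follows:

compound 1 `Nc1sc2c(c1-c1nc3cc(Cl)ccc3s1)CCC2` — 67.8 ug/mL
compound 2 `Clc1ccc(/C=N/c2sc3c(c2-c2nc4ccccc4s2)CCCC3)cc1` — 397 ug/mL
compound 3 `COc1cc(/C=N/c2sc3c(c2-c2nc4ccccc4s2)CCCC3)cc(OC)c1OC` — 301 ug/mL

Compound 2 gives the highest of the three numbers. Compound 3 lies within the scatter of it, while compound 1 lies beyond the scatter and lower. For the measured compounds named here, no pair of measured compounds differs in a single place, so no isolated step is available. Compound 4 `C(=C/c1ccccc1)\C=N\c1sc2c(c1-c1nc3ccccc3s1)CCCC2` differs from compound 2 by 2-phenylethenyl in place of 4-chlorophenyl on a carbon with a double bond to nitrogen. Compound 2 and compound 3 carry different groups on the carbon with a double bond to nitrogen yet fall within the scatter of each other, so for compound 4 no step beyond the scatter in either direction is expected, a 1.3-fold lower number from compound 2 to compound 4 (0.12 log units; within the scatter). Compound 4 is therefore estimated at 300 ug/mL in this assay, within a range of 130 ug/mL to 600 ug/mL.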

Compound 4, half-maximal cytotoxic concentration: 467 ug/mL
Compound 4: middle estimate off by 1.6-fold (0.19 log units), on the low side, and the stated range covers the measured number.
By their numbers in this assay, from the lowest: compound 1; then compounds 3, 2 and 4 (each within the scatter of the next).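

In this assay, for the compounds shown here, 2-phenylethenyl in place of 4-chlorophenyl on a carbon with a double bond to nitrogen gives a 1.2-fold higher number from compound 2 to compound 4 (0.07 log units; within the scatter) as the first single-place step at this position. Losing the chlorine and adding a double bond outside aromatic rings thus leaves the number within the scatter. No measurement at hand bears on the reason for this result. Open, as far as these compounds go, is whether this position stays as tolerant with a group lacking an aromatic ring, such as a longer chain, or with a carboxylic acid on the phenyl ring.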